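The compounds below may be only part of what the source reports. "The series", "measured", "known", "first", "only" and "open" are said of these compounds alone.

Three compounds built on one shared core have been examined in an ADME assay on cells (Macrophage, Homo sapiens) for inhibition; a lower number here means that less compound is tolerated, a higher number that more compound is tolerated. Compound 1 `c1ccc(Cc2nnc(Cn3nnc4ccccc43)o2)cc1` is the parent. In this assay compound 1 reaches only the limit > 100000 nM. Compound 2 `Brc1ccc(Cc2nnc(Cn3nnc4ccccc43)o2)cc1` carries bromo in place of hydrogen on an aromatic carbon. In this assay compound 2 likewise stops at the limit > 100000 nM. Compound 3 `Fc1cccc(Cc2nnc(Cn3nnc4ccccc43)o2)c1` carries fluoro in place of hydrogen on an aromatic carbon. In this assay compound 3 also gives only the limit > 100000 nM. Because all three values sit at the limit of > 100000 nM in this assay, at which 3 of the 3 values shown sit, the steps between them cannot be sized: a step that the two limits leave unreadable from compound 1 to compound 2, a step that the two limits leave unreadable from compound 1 to compound 3 and a step that the two limits leave unreadable from compound 2 to compound 3 are each unreadable. Compound 4 `COc1cccc(Cc2nnc(Cn3nnc4ccccc43)o2)c1` differs from compound 3 by methoxy in place of fluoro on an aromatic carbon. No measured step gives a readable size or direction, so nothing among these compounds argues for a change that this assay could resolve. The step from compound 3 to compound 4 is expected to be a step that the limit leaves unreadable from compound 3 to compound 4. Compound 4 is estimated at 150000 nM, within a range from 50000 nM to 500000 nM, and most likely the assay again reports only a limit.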

Compound 4, half-maximal cytotoxic concentration: > 100000 nM
Compound 4: no number, only a limit; the forecaster's own chance of this, stated with the estimate: 85%; the middle value lies beyond the limit too.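

Going by these compounds alone, no step from compound 1, compound 2 or compound 3 to compound 4 can be read in this assay, because all four compounds stop at a limit: (the limit of > 100000 nM in this assay, at which 4 of the 4 values shown sit). Whether any change on the shared core can give a readable number in this assay stays open among the compounds shown.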